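The source may report more compounds than this note shows. Statements on the series, on what has been measured and on what is new or still open speak of the compounds shown alone.

- compound 1 `O=c1c2ccccc2c(-c2cccnc2)nn1C1CCCC1`: 2750 nM
- compound 2 `COCCn1nc(-c2cccnc2)c2ccccc2c1=O`: 9330 nM

In a functional assay (trachea) with Cavia porcellus as the target (a lower number here means a stronger inhibitor, a higher number a weaker inhibitor), compound 2 holds the higher of the two numbers, at 9330 nM, making it the weaker inhibitor so far. The next compound, compound 3 `O=c1c2ccccc2c(-c2cccnc2)nn1CCSc1nccs1`, keeps the shared core and changes the end of the chain: (1,3-thiazol-2-yl)sulfanyl in place of methoxy on a saturated chain carbon, two bonds along the chain from an aromatic nitrogen. Among the compounds with values here, only one measured step bears on this change, a 3.4-fold higher number from compound 1 to compound 2 (0.53 log units; beyond the scatter), a modest change on the same aromatic nitrogen. Within the data shown here, no measured compound carries the new group, so the evidence is thin. Still, the one substituent with a ring, in compound 1, gives 2750 nM, which suggests that a ring-bearing group may lower the number. The expected change is of similar modest size and towards a lower number, a 2.7-fold lower number from compound 2 to compound 3 (0.43 log units; beyond the scatter). For compound 3 the estimated value is 3500 nM, with an expected range from 900 nM to 13000 nM.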

Compound 3, half-maximal inhibitory concentration: 10500 nM
Compound 3: the middle estimate sits 3.0-fold (0.48 log units) below what was measured; the range from low to high includes it.
By their numbers in this assay, from the lowest: compound 1; then compounds 2 and 3 (each within the scatter of the next).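

In this assay, replacing methoxy with (1,3-thiazol-2-yl)sulfanyl on a saturated chain carbon, two bonds along the chain from an aromatic nitrogen, gives a 1.1-fold higher number from compound 2 to compound 3 (0.05 log units; within the scatter), so this much larger group with its aromatic ring makes no difference beyond the scatter. Set against the cyclopentyl of compound 1, the new substituent gives a 3.8-fold higher number from compound 1 to compound 3 (0.58 log units; beyond the scatter), which shows that a ring within the substituent is not enough to reach the number of compound 1. Nothing available accounts for either result.

The compounds shown leave open whether a 2-cyclopentylethyl group, with the same chain but a saturated ring at its end, would stay with compound 2 and compound 3 or approach compound 1. They also leave open how an amine or a carboxylic acid at the end of the chain would read, and whether a cyclohexyl or phenyl group on the aromatic nitrogen would lower the number further.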